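The source may hold more compounds than are shown below. What is called first, only, known or untested is meant among the compounds shown, and "the series" means these compounds.

Notes on the series. In a functional assay on CCRF-CEM cells for antagonist activity at C-X-C chemokine receptor type 4 (Homo sapiens), read by calcium flux, with stated times of 25 min and 90 s (on this read-out higher numbers stand for weaker inhibition and lower numbers for stronger inhibition), compound 1 `CN(C[C@@H]1Cc2c(cccc2N2CCNCC2)CN1)[C@H]1CCCc2cccnc21` gives 313 nM. Among the compounds with values here, compound 2 `CN(C[C@H]1Cc2c(cccc2N2CCN(C3CC3)CC2)CN1)[C@H]1CCCc2cccnc21` carries the lowest of the two numbers so far: in this assay compound 2 gives 23.5 nM, and the nearest number, that of compound 1, lies higher by a margin beyond the scatter. Within the data shown here, no single-change step between measured compounds is available, so compound 2 is read as the better-placed reference.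

Compound 3 `CN(C[C@H]1Cc2c(cccc2N2CCN3CCC[C@H]3C2)CN1)[C@H]1CCCc2cccnc21` is the next point. Relative to compound 2 the change is a group of 9 heavy atoms (7 carbon, 2 nitrogen; one five-membered non-aromatic ring with 1 hetero atom, one six-membered non-aromatic ring with 2 hetero atoms) in place of a group of 9 heavy atoms (7 carbon, 2 nitrogen; one three-membered non-aromatic ring of carbon only, one six-membered non-aromatic ring with 2 hetero atoms), on an aromatic carbon. Both the leaving and the entering group keep a six-membered non-aromatic ring with two hetero atoms on the same aromatic carbon, and both count the same hydrogen-bond acceptors and donors, so no step beyond the scatter is expected in this assay for compound 3, with a modest loss treated as the more likely side. The estimate for compound 3 is 40 nM (range 12 nM to 150 nM), which is expected to mean a step of a 1.7-fold higher number from compound 2 to compound 3 (0.23 log units; within the scatter).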

Compound 3, half-maximal inhibitory concentration: 2.92 nM
Beside the measured number, compound 3's estimate is 14-fold (1.14 log units) above it; the measured number lies below the stated range.
By their numbers in this assay, from the lowest: compound 3; then compound 2; then compound 1.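

In this assay, the change on this aromatic carbon gives an 8.0-fold lower number from compound 2 to compound 3 (0.91 log units; beyond the scatter), so at this position the counts alone do not settle the result: 4-cyclopropylpiperazin-1-yl and the entering group have the same heavy atoms, the same hydrogen-bond donors and acceptors and no net charge, and differ only in how the atoms are joined. The arrangement of those atoms therefore matters here, with a five-membered non-aromatic ring and a defined stereocentre in place of a three-membered ring of carbon only. Nothing available gives a reason for this lower number.

Open, as far as these compounds go, is whether the opposite configuration at the defined stereocentre of the entering group would keep this number. Also open, from the compounds shown here alone, is where a piperazine bearing a plain methyl or isopropyl group would fall on this read-out.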